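Butoxy in place of 4-(difluoromethoxy)phenyl on a carbonyl carbon

This account rests on a few compounds, and the source may have more. Where it says the series, first, only, none or still open, it means among the compounds named here.

In an ADME assay on Vero cells (Chlorocebus sabaeus) for cytotoxicity, read by resazurin assay, with a stated time of 3 days (a higher number here means a weaker inhibitor, a lower number a stronger inhibitor), compound 3 `CCN(CC)c1cc2[nH]c(C3CCCCC3)nc2cc1NC(=O)c1ccc(OC(F)F)cc1` gives > 100 ug/mL, which is a limit of the assay and not a number. Compound 1 `CCCCNC(=O)Nc1cc2nc(C3CCCCC3)[nH]c2cc1N(CC)CC` gives > 100 ug/mL, which is also a limit. Compound 2 `CCCCOC(=O)Nc1cc2nc(C3CCCCC3)[nH]c2cc1N(C)C`, which carries butoxy on a carbonyl carbon, gives > 100 ug/mL, again a limit. Compound 3 therefore has no exact place among these compounds, and all that can be said is that every reading so far is the limit of > 100 ug/mL in this assay, at which 3 of the 3 values shown sit.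

The next compound, compound 4 `CCCCOC(=O)Nc1cc2nc(C3CCCCC3)[nH]c2cc1N(CC)CC`, has butoxy in place of 4-(difluoromethoxy)phenyl on a carbonyl carbon. One measured step changes a group at that same kind of carbonyl carbon, namely a step that the two limits leave unreadable from compound 1 to compound 3. Its size cannot be read, so it offers no number to carry over. No step beyond the usual scatter is expected in this assay, because the limit of > 100 ug/mL in this assay, at which 3 of the 3 values shown sit, holds for compound 1, compound 2 and compound 3 alike. The estimated change is a number no higher from compound 3 to compound 4 (the limit leaves the size open), with no direction expected, and the assay will most likely report a limit again. For compound 4 the estimated value is 100 ug/mL, with an expected range from 50 ug/mL to 200 ug/mL.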

Compound 4, half-maximal inhibitory concentration: > 100 ug/mL
Compound 4 ended at the assay's limit; the forecaster's own chance of this, stated with the estimate: 85%; the middle value sits exactly at the limit.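

Compound 4 reads as a limit, as do compound 1, compound 2 and compound 3, so no step among these compounds can be read in this assay: the limit of > 100 ug/mL in this assay, at which 4 of the 4 values shown sit.

The compounds shown leave open whether butoxy, butylamino or 4-(difluoromethoxy)phenyl on a carbonyl carbon, or diethylamino in place of dimethylamino on an aromatic carbon, changes the reading at all.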